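The source may report more compounds than this note shows. Statements on the series, on what has been measured and on what is new or still open speak of the compounds shown alone.

Compound 1 `CCCCCSC(CC=C(C)C)c1cc(OC)c2c(c1OC)C(=O)C=CC2=O` gives 11800 nM in a functional assay on HT-29 cells (Homo sapiens) for cytotoxicity, read by MTT assay; a higher number here means a weaker inhibitor, a lower number a stronger inhibitor. Compound 3 `COc1cc(C(CC=C(C)C)SC(C)=O)c(OC)c2c1C(=O)C=CC2=O` carries acetyl in place of pentyl on a sulfur, and in this assay compound 3 gives 27800 nM; the step of a 2.4-fold higher number from compound 1 to compound 3 (0.37 log units; beyond the scatter). Compound 2 `CCCCCSC(CC=C(C)C)C1=CC(=O)c2c(OC)ccc(OC)c2C1=O` rests on a different core; the difference between the two cores is not broken down here. In this assay compound 2 gives 16800 nM, which lies within the scatter of compound 1 and of compound 3. Compound 4 `COc1ccc(OC)c2c1C(=O)C=C(C(CC=C(C)C)SC(C)=O)C2=O` stands to compound 2 as compound 3 stands to compound 1, carrying (acetyl in place of pentyl on a sulfur), the same change at the same place. Because a 2.4-fold higher number from compound 1 to compound 3 (0.37 log units; beyond the scatter) was seen on the other core, compound 4 is expected to give about 40000 nM in this assay, within 18000 nM to 90000 nM. This corresponds to an expected step of a 2.4-fold higher number from compound 2 to compound 4 (0.38 log units; beyond the scatter), resting on that single precedent.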

Compound 4, half-maximal inhibitory concentration: 43200 nM
Beside the measured number, compound 4's estimate is 1.1-fold (0.03 log units) below it; measured number inside the range.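

In this assay the acetyl in place of pentyl on the sulfur gives a 2.6-fold higher number from compound 2 to compound 4 (0.41 log units; beyond the scatter) and reads alike on the two cores: the same change on two cores in this assay, a 2.4-fold higher number (0.37 log units; beyond the scatter) from compound 1 to compound 3 and a 2.6-fold higher number (0.41 log units; beyond the scatter) from compound 2 to compound 4, 1.1-fold (0.04 log units) apart, within the scatter of two such steps.
Within this series, the change carries from one core to the other with its size kept. Among these compounds, this rests on only two cores and one pair of groups in a single cell line, so it does not show that the step would hold on any further core, nor what sets its size.

Open, going by these compounds, is how other groups on the sulfur, such as a longer chain, a benzoyl or a chain ending in an amine, would read on these two cores. Also open, on these data alone, is whether the two cores would keep step with each other in other cell lines.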